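Straight chains versus a branched chain on the shared core

This account rests on a few compounds, and the source may have more. Where it says the series, first, only, none or still open, it means among the compounds named here.

Measured so far in a functional assay on the whole organism with Rattus norvegicus as the target; on this read-out higher numbers stand for an effect only at larger amounts of compound and lower numbers for an effect already at smaller amounts:
Compound 1 `CCCCc1ccc(-c2c(C)[nH]c(=O)n2C)cc1` gives 0.1 mg/kg.
Compound 2 `CCCCOc1ccc(-c2c(C)[nH]c(=O)n2C)cc1` gives 0.3 mg/kg.
Compound 3 `Cc1[nH]c(=O)n(C)c1-c1ccc(CC(C)C)cc1` gives 30 mg/kg.

Compound 3 stands at the highest number of the three: compound 2 stands a good way below it, and compound 1 furthest below. The step from compound 3 to the unmeasured compound 4 `CCCCCCc1ccc(-c2c(C)[nH]c(=O)n2C)cc1` is pentyl in place of isopropyl on a saturated chain carbon bound to an aromatic carbon. Among the measured compounds shown here, two measured steps bear on it. For the measured compounds named here, the branched isopropyl arrived in the step of a 300-fold higher number from compound 1 to compound 3 (2.48 log units; beyond the scatter), a large rise in number, and the step of a 100-fold higher number from compound 2 to compound 3 (2.00 log units; beyond the scatter) points the same way, so compound 3 carries the only branched chain and the only large number. Going by the values given here, compound 4 returns to a straight chain, as in compound 1, but two carbons longer; no measured pair speaks to chain length on its own. The expectation is therefore a large fall in the number, reversing most of what the branching brought, with some uncertainty left for the longer chain. Compound 4 is estimated at 0.3 mg/kg, with a range from 0.05 mg/kg to 3 mg/kg, which means an expected step of a 100-fold lower number from compound 3 to compound 4 (2.00 log units; beyond the scatter).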

Compound 4, minimum effective dose: 0.3 mg/kg
Estimate against measurement, compound 4: no gap at the digits printed; measured number inside the range.
By their numbers in this assay, from the lowest: compound 1; then compounds 2 and 4 (each within the scatter of the next); then compound 3.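

In this assay, extending the straight chain by ethyl gives a 3.0-fold higher number from compound 1 to compound 4 (0.48 log units; beyond the scatter), only a modest rise, whereas pentyl in place of isopropyl gives a 100-fold lower number from compound 3 to compound 4 (2.00 log units; beyond the scatter). Chain size alone therefore does not account for the high number of compound 3: compound 4 has the longer chain, yet its number is far lower than that of the branched isobutyl compound. Among the compounds shown here, this adds a first read on chain length, which the earlier compounds could not give, although a single lengthening step cannot establish a trend. Hexyl in place of butoxy gives no change at the digits printed from compound 2 to compound 4 (within the scatter), so these two straight-chain substituents cannot be told apart on this read-out.

Nothing available here explains why the branched compound stands so far from the straight-chain compounds, or why the longer chain shifts the number slightly from that of compound 1. Also open, on these data alone, is how an octyl chain, a cyclohexyl ring or a chain ending in an amine would behave, and whether the large rise seen with isobutyl would recur with another branched chain, such as 2-methylbutyl.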